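The source may report more compounds than this note shows. Statements on the series, on what has been measured and on what is new or still open speak of the compounds shown alone.

Working notes on the series.

Compound 3 `O=C(O)CCn1c(=O)oc2cc(OCC3CCC3)c(Cl)cc21` gives the lowest number of the three measured in an assay on HEK293 cells for inhibition of kynurenine 3-monooxygenase (Homo sapiens), read by LC-MS, with a stated time of 20 h (a lower number here means a stronger inhibitor, a higher number a weaker inhibitor), with compound 3 at 1260 nM. The parent, compound 1 `COc1cc2oc(=O)n(CCC(=O)O)c2cc1Cl`, sits at 5010 nM; the step of a 4.0-fold lower number from compound 1 to compound 3 (0.60 log units; beyond the scatter) lies beyond the scatter. Compound 2 `COCCOc1cc2oc(=O)n(CCC(=O)O)c2cc1Cl` is the weakest of the three, at 50100 nM in this assay, and the step of a 40-fold lower number from compound 2 to compound 3 (1.60 log units; beyond the scatter) is the largest in the set.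

The next compound, compound 4 `C[C@@H](Oc1cc2oc(=O)n(CCC(=O)O)c2cc1Cl)c1ncco1`, differs from compound 3 in one place: a group of 7 heavy atoms (5 carbon, 1 nitrogen, 1 oxygen; one five-membered aromatic ring with 2 hetero atoms) in place of a group of 5 heavy atoms (5 carbon; one four-membered non-aromatic ring of carbon only), on an oxygen on an aromatic ring

Among the compounds with values here, two measured steps bear on this. Adding a carbon ring on the chain carbon bound to the aromatic oxygen lowered the number, a 4.0-fold lower number from compound 1 to compound 3 (0.60 log units; beyond the scatter), whereas adding a group carrying an oxygen on that same carbon raised it, a 10-fold higher number from compound 1 to compound 2 (1.00 log units; beyond the scatter). The entering group in compound 4 carries both an aromatic ring and two hetero atoms, so a number between those two outcomes is expected in this assay, most likely a rise from compound 3. The step of a 4.0-fold higher number from compound 3 to compound 4 (0.60 log units; beyond the scatter) is the expected size. Compound 4 is therefore estimated at 5000 nM, within 1500 nM to 16000 nM.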

Compound 4, half-maximal inhibitory concentration: 7940 nM
The estimate for compound 4 lay 1.6-fold (0.20 log units) below the measured number, within the range that was stated.
By their numbers in this assay, from the lowest: compound 3; then compounds 1 and 4 (each within the scatter of the next); then compound 2.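

At this place, on an oxygen on an aromatic ring, the five-membered aromatic ring with 2 hetero atoms does not keep the gain seen with cyclobutylmethyl: this assay gives a 6.3-fold higher number from compound 3 to compound 4 (0.80 log units; beyond the scatter) for this change. The same entering group still compares well with the open chain of compound 2, as a 6.3-fold lower number from compound 2 to compound 4 (0.80 log units; beyond the scatter) shows, so a group with hetero atoms need not carry the full cost seen with that chain. Against the parent, a 1.6-fold higher number from compound 1 to compound 4 (0.20 log units; within the scatter) lies within the scatter, so this much larger group can be accommodated here without a step that can be read.

The change alters ring type, hetero atoms and the defined stereocentre together, and a phenyl ring on the same carbon would help to separate these. No measurement in hand accounts for any of these steps.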